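Cyclohexyl for Hexyl on an Alkynyl Nucleoside

The source may hold more compounds than are shown below. What is called first, only, known or untested is meant among the compounds shown, and "the series" means these compounds.

Three compounds have been measured in an ADME assay on Vero cells (Chlorocebus sabaeus) for cytotoxicity, read by MTT assay; on this read-out higher numbers stand for lower toxicity in this test and lower numbers for higher toxicity in this test:
compound 1 `CCCCCCC#Cc1cn([C@@H]2O[C@H](CO)[C@@H](O)[C@H]2O)c(=O)[nH]c1=O` gives 111000 nM
compound 2 `O=c1[nH]cc(C#CC(O)c2ccccc2)c(=O)[nH]1` gives 242000 nM
compound 3 `O=c1[nH]cc(C#Cc2ccccc2)c(=O)[nH]1` gives 255000 nM

Compound 1 stands lowest of the three in this assay; compound 2 is its nearest neighbour and compound 3 its furthest, and both gaps lie beyond the usual scatter. Compound 4 `O=c1[nH]c(=O)n([C@@H]2O[C@H](CO)[C@@H](O)[C@H]2O)cc1C#CC1CCCCC1` has not yet been measured. It differs from compound 1 in one place: cyclohexyl in place of hexyl on a triple-bonded carbon. For the measured compounds named here, no pair of measured compounds shows this change, so the expectation rests on compound 1 alone. Compound 4 is expected to stay near compound 1, with the step of a 1.1-fold higher number from compound 1 to compound 4 (0.03 log units; within the scatter) not beyond the scatter in either direction. The estimate for compound 4 is 120000 nM, within a range from 50000 nM to 300000 nM.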

Compound 4, half-maximal cytotoxic concentration: 148000 nM
The estimate for compound 4 lay 1.2-fold (0.09 log units) below the measured number, and the stated range covers the measured number.
By their numbers in this assay, from the lowest: compounds 1, 4, 2 and 3 (each within the scatter of the next, the first and the last beyond it).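

In this assay, cyclohexyl in place of hexyl on a triple-bonded carbon gives a 1.3-fold higher number from compound 1 to compound 4 (0.12 log units; within the scatter), the first step read at this position. The read-out therefore does not separate the open chain from the six-membered ring of carbon only, which carry the same count of heavy atoms. Nothing at hand explains this result. The compounds shown leave open whether a longer chain at this place would also stay within the scatter of compound 1. They also leave open what an amine or a carboxylic acid on the cyclohexyl would do.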